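From chloro to bromo on the shared core

The compounds below may be only part of what the source reports. "The series", "measured", "known", "first", "only" and "open" are said of these compounds alone.

In a functional assay on the whole organism for positive allosteric modulation, with Mus musculus as the target (a higher number here means that more compound is needed for the effect, a lower number that less compound is needed), compound 1 `CCC(=O)N(c1ccc(Cl)cc1)C1CCCC1N(C)C` gives 3 mg/kg as its dose. Compound 3 `CCC(=O)N(c1ccc(Cl)c(C)c1)C1CCCC1N(C)C` gives 2 mg/kg in the same test, which is a 1.5-fold lower number from compound 1 to compound 3 (0.18 log units; within the scatter) for methyl in place of hydrogen on an aromatic carbon. Compound 2 `CCC(=O)N(c1ccc(C)cc1)C1CCCC1N(C)C` gives 30 mg/kg; 30 mg/kg (2 entries) with methyl in place of chloro, a clearly higher number than compound 1 shows. Compound 4 `CCC(=O)N(c1ccc(Br)cc1)C1CCCC1N(C)C` is still unmeasured and carries bromo in place of chloro on an aromatic carbon, para to a large group (bromo in place of chloro on an aromatic carbon). Within the data shown here, no measured step makes this exact exchange, and the step to compound 3 bears on it only loosely. The expected step is no change at the digits printed from compound 1 to compound 4 (within the scatter) and so stays within the scatter. Compound 4 is estimated at 3 mg/kg with 1 mg/kg to 10 mg/kg as its likely range.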

Compound 4, dose for half-maximal effect: 2 mg/kg
Estimate against measurement, compound 4: 1.5-fold (0.18 log units) above; the range from low to high includes it.
By their numbers in this assay, from the lowest: compounds 3, 4 and 1 (each within the scatter of the next).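

Placing bromo instead of chloro on this aromatic carbon gives a 1.5-fold lower number from compound 1 to compound 4 (0.18 log units; within the scatter) in this assay, so this test does not separate the two groups at this position. With bromo, compound 4 gives 2 mg/kg, while with methyl at the same place, compound 2 gives 30 mg/kg; 30 mg/kg (2 entries) in the same test. No measurement shown explains why bromo and chloro behave alike here.

Still open, on these data alone, is whether fluoro, trifluoromethyl or methoxy at this position would give a dose like that of bromo and chloro. Also open, as far as these compounds go, is how bromo would behave alongside the extra ring methyl of compound 3.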